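A few compounds are considered here, and "the series" means these few. Any claim that something is new, unique, unknown or untested is made for them only; others in the source may bear on it.

Measured so far:
compound 1, `CCCc1c(OCCCCOc2ccc(-c3nn[nH]n3)cc2)ccc2c1ccn2CC(C)(C)C`: 559 nM
compound 2, `CCCc1c(OCCCCOc2ccc(-c3nn[nH]n3)cc2)ccc2c1nnn2CC(C)(C)C`: 188 nM

Both numbers come from a functional assay for binding affinity to metabotropic glutamate receptor 2 (Homo sapiens), read by GTPgammaS binding, with a stated time of 1 h, at 30 degrees C; on this read-out higher numbers stand for an effect only at larger amounts of compound and lower numbers for an effect already at smaller amounts. Compound 1 stands highest of the two numbers; compound 2, the nearest, gives the lower number, and the gap between the two lies beyond the scatter. Within the data shown here, no step between measured compounds that differ in one place is available, so the comparison of compound 1 with compound 2 rests on the two values alone and cannot be tied to a single change.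

The unmeasured compound 3 is `CCCCCn1ccc2c(CCC)c(OCCCCOc3ccc(-c4nn[nH]n4)cc3)ccc21`. It differs from compound 1 in one place: butyl in place of tert-butyl on a saturated chain carbon bound to an aromatic nitrogen The atoms are the same, joined differently; cut one bond further out, the change reads neopentyl to pentyl. Among the measured compounds shown here, no measured pair shows this change, so there is nothing to lean on beyond compound 1 itself. The expected step in this assay is none beyond the scatter, in either direction, with the uncertainty widened accordingly. The expected step is a 1.1-fold higher number from compound 1 to compound 3 (0.03 log units; within the scatter). The estimate for compound 3 is 600 nM. The expected range for compound 3 runs from 250 nM to 1500 nM.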

Compound 3, half-maximal effective concentration: 598 nM
Beside the measured number, compound 3's estimate is 1.0-fold (0.00 log units) above it, and the stated range covers the measured number.
By their numbers in this assay, from the lowest: compound 2; then compounds 1 and 3 (each within the scatter of the next).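

In this assay, among these compounds, the move to butyl in place of tert-butyl on a saturated chain carbon bound to an aromatic nitrogen gives a 1.1-fold higher number from compound 1 to compound 3 (0.03 log units; within the scatter), the first step that can be tied to a single change. With the same four carbons joined differently, the reading stays within the scatter, so on the core of compound 1 this position shows no dependence on how those carbons are arranged. That finding is limited to this one rearrangement of a group of unchanged atom count and leaves the effect of any other substituent at this place untested, and no available evidence gives a reason for the outcome.

The compounds shown leave open whether this position would respond to a change of size or kind, such as a shorter chain like ethyl, a longer chain like heptyl, or a chain ending in an amine or a carboxylic acid. Among the compounds shown here, they also leave open whether the same exchange of tert-butyl for butyl would read the same way on the core of compound 2, where no such pair is available.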